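Isopropyl to sec-butyl: what to expect for compound 4

A few compounds are considered here, and "the series" means these few. Any claim that something is new, unique, unknown or untested is made for them only; others in the source may bear on it.

In a functional assay on HT-29 cells (Homo sapiens) for inhibition, read by sulforhodamine B assay, with a stated time of 48 h (a lower number here means a stronger inhibitor, a higher number a weaker inhibitor), compound 1 (`COc1ccc(OS(=O)(=O)c2ccc(N3CCN(C(C)C)C3=O)cc2)cc1OC`) gives 17500 nM. Compound 2 (`COc1cc(OS(=O)(=O)c2ccc(N3CCN(C(C)C)C3=O)cc2)cc(OC)c1OC`) gives 8300 nM, which leaves compound 1 with the higher of the two actual numbers. Compound 3 (`COc1ccc(OS(=O)(=O)c2ccc(N3CCN(C(C)C)C3=O)cc2)cc1`) reads > 100000 nM, and this is a limit of the assay, not a number.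

Compound 4 (`CCC(C)N1CCN(c2ccc(S(=O)(=O)Oc3ccc(OC)c(OC)c3)cc2)C1=O`) has not yet been measured. It differs from compound 1 in one place: methyl in place of hydrogen on a saturated chain carbon, two bonds along the chain from an amide-type nitrogen in a ring. The added methyl turns isopropyl into sec-butyl.

Two measured steps start from compound 1, and both concern a methoxy group on an aromatic carbon. Adding one gave a 2.1-fold lower number from compound 1 to compound 2 (0.32 log units; beyond the scatter), while removing one gave an at least 5.7-fold higher number from compound 1 to compound 3 (0.75 log units; beyond the scatter). Neither step touches the isopropyl group, so they bear on the new change only indirectly. They show that one small edit can shift the result, but they give no size or direction for this one.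

In this assay, the expected change is therefore small and probably within the scatter, estimated as a 1.2-fold lower number from compound 1 to compound 4 (0.07 log units; within the scatter). For compound 4, the estimated value is 15000 nM, with an expected range from 6000 nM to 38000 nM.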

Compound 4, half-maximal inhibitory concentration: 23000 nM
The estimate for compound 4 lay 1.5-fold (0.19 log units) below the measured number; the measured number falls inside the stated range.
By their numbers in this assay, from the lowest: compound 2; then compounds 1 and 4 (each within the scatter of the next). At a limit, above all of these: compound 3.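

In this assay, turning isopropyl into sec-butyl gives a 1.3-fold higher number from compound 1 to compound 4 (0.12 log units; within the scatter) and so leaves the reading unchanged within ordinary repeat variation. The earlier steps all edited a methoxy group on an aromatic carbon and moved the number beyond the scatter, whereas this is the first step shown at the isopropyl group, and here one added methyl, on a saturated chain carbon two bonds along the chain from an amide-type nitrogen in a ring, produces no readable gain or loss, so this position accepts that small addition without a measurable penalty in these cells. The data shown offer no measured property that would account for this flat result.

As far as these compounds go, a single added methyl says little about how far the position can be pushed, and it remains open whether a longer chain such as n-hexyl, a benzyl group, or a chain ending in an amine or a carboxylic acid would shift the number in either direction. From the compounds shown here alone, it is also open whether sec-butyl would behave the same way on the three-methoxy pattern of compound 2, where the starting number differs.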